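A few compounds are considered here, and "the series" means these few. Any claim that something is new, unique, unknown or untested is made for them only; others in the source may bear on it.

Working notes on the series. Going by the values given here, in an assay on membranes from CHO cells for displacement of a labelled ligand from adenosine receptor A1 (Homo sapiens), read by scintillation counting, with a stated time of 60 min, tested at 1 uM (on this read-out higher numbers stand for more inhibition at the one concentration tested (going by the name of the read-out) and lower numbers for less inhibition), compound 1 `CCCC(=O)C1=C(C)NC(=O)NC1c1ccoc1` gives 1% and compound 2 `CCNC(=O)C1=C(C)NC(=O)NC1c1ccoc1` gives 1%; the step of no change at the digits printed from compound 1 to compound 2 (within the scatter) is the only one-place step measured so far. Compound 3 `CCSC(=O)C1=C(C)NC(=O)NC1c1ccco1` gives 6% in this assay, a number within the scatter of compound 1 and of compound 2, so the three values cannot be ordered.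

Compound 4 `CCSC(=O)C1=C(C)NC(=O)NC1c1ccoc1` differs from compound 3 by furan-3-yl in place of furan-2-yl on a saturated ring carbon. Among the compounds with values here, no measured step touches this change: the step from compound 1 to compound 2 alters the group on the carbonyl carbon while both carry furan-3-yl, and compound 3 carries furan-2-yl alongside a different carbonyl group, so its pair with compound 1 or compound 2 is not a single step. What the values show is that all three compounds sit near the bottom of the read-out whichever furan is attached. For compound 4 the step of a number 3 percentage points lower from compound 3 to compound 4 (within the scatter) is therefore expected to stay within the scatter. The estimate for compound 4 in this assay is 3%, with a range from -5% to 12%.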

Compound 4, a percentage reported as inhibition, at one concentration (the size of the read-out at that concentration, not a potency): 3%
The estimate for compound 4 equals the measured number at the digits printed; measured number inside the range.
By their numbers in this assay, from the lowest: compounds 1, 2, 4 and 3 (each within the scatter of the next).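

With the ethylsulfanyl carbonyl group held constant, the change on the saturated ring carbon can now be read directly in this assay (a number 3 percentage points lower from compound 3 to compound 4 (within the scatter)), and furan-3-yl and furan-2-yl do not separate there. With furan-3-yl held constant, ethylsulfanyl on the carbonyl carbon can be read against ethylamino (a number 2 percentage points higher from compound 2 to compound 4 (within the scatter)) and against propyl (a number 2 percentage points higher from compound 1 to compound 4 (within the scatter)), so that place shows no separation among these three groups either. No supporting data bear on the origin of these values.

Going by these compounds, all four compounds sit near the bottom of the read-out, so it stays open whether the choice of furan would matter in a compound giving more inhibition. Also open, on these data alone, is how a phenyl ring on the saturated ring carbon, or a carboxylic acid or longer chain on the carbonyl carbon, would read.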